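From Methyl to 1-Aminoethyl in Compound 4

The source may hold more compounds than are shown below. What is called first, only, known or untested is meant among the compounds shown, and "the series" means these compounds.

- Compound 1 `Cc1c2c(n3c1CCN(C(=O)[C@H](C)N)CC[C@H](C)Nc1cc-3ccc1C(N)=O)CC(C)(C)CC2=O`: > 100 ug/mL
- Compound 2 `CC(=O)NCC(=O)N1CCc2c(C)c3c(n2-c2ccc(C(N)=O)c(c2)N[C@@H](C)CC1)CC(C)(C)CC3=O`: 5 ug/mL
- Compound 3 `CC(=O)N1CCc2c(C)c3c(n2-c2ccc(C(N)=O)c(c2)N[C@@H](C)CC1)CC(C)(C)CC3=O`: 19 ug/mL

In a physicochemical assay for solubility (on this read-out higher numbers stand for higher solubility and lower numbers for lower solubility), compound 3 gives 19 ug/mL, the higher of the two values that are true numbers, and the gap is a 3.8-fold higher number from compound 2 to compound 3 (0.58 log units; beyond the scatter). Compound 1 gives > 100 ug/mL, which is a limit of the assay and not a number. Compound 4 `Cc1c2c(n3c1CCN(C(=O)[C@@H](C)N)CC[C@H](C)Nc1cc-3ccc1C(N)=O)CC(C)(C)CC2=O` differs from compound 3 by 1-aminoethyl in place of methyl on a carbonyl carbon. The measured step that bears on this is the same swap read backward, an at least 5.2-fold lower number from compound 1 to compound 3 (0.72 log units; beyond the scatter). How the arrangement at the defined stereocentre counts is unmeasured. Given that step from compound 1, the expected change in this assay is a 6.3-fold higher number from compound 3 to compound 4 (0.80 log units; beyond the scatter). The estimated value for compound 4 is 120 ug/mL, within a range of 40 ug/mL to 300 ug/mL.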

Compound 4, solubility: > 100 ug/mL
Compound 4: a limit, no number; the forecaster's own chance of this, stated with the estimate: 60%; the middle value lies beyond the limit too.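

Compound 4 shows that the high reading in this assay does not depend on the S configuration drawn in compound 1, since the R form also reaches the limit. Replacing the smaller groups with 1-aminoethyl gives an at least 5.2-fold higher number from compound 3 to compound 4 (0.72 log units; beyond the scatter) and an at least 20-fold higher number from compound 2 to compound 4 (1.30 log units; beyond the scatter). The step between compound 1 and compound 4 cannot be read, because both sit at a limit: the limit of > 100 ug/mL in this assay, at which 2 of the 4 values shown sit.

From the compounds shown here alone, whether configuration changes the true value therefore stays open, although this pair would be a direct test of it: the fact that compounds 1 and 4 differ only in the configuration as drawn Also open is how a carboxylic acid or a longer amine chain would read at this position.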